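The compounds below may be only part of what the source reports. "The series", "measured", "known", "first", "only" and "open" are said of these compounds alone.

Measured in a functional assay on OVCAR-3 cells (Homo sapiens) for inhibition, read by sulforhodamine B assay, with a stated time of 48 h; on this read-out higher numbers stand for weaker inhibition of growth and lower numbers for stronger inhibition of growth:
- compound 1 `CCOC(=O)c1nn(-c2ccc(Cl)cc2)c(-c2ccc(C)cc2)c1CNC(C)(C)C`: 49200 nM; > 542000 nM (2 entries)
- compound 2 `CC(C)(C)NCc1c(C(=O)O)nn(-c2ccc(Cl)cc2)c1-c1ccc(Cl)cc1`: 84900 nM
- compound 3 `CC(C)(C)NCc1c(C(=O)O)nn(-c2ccc(Cl)cc2)c1-c1ccccc1`: 653000 nM

One entry of compound 1 is a limit of the assay, and its entries give no single number. Of the two compounds with a single number, compound 3 stands higher, with compound 2 as its nearest neighbour.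

Compound 4 `Cc1ccc(-c2c(CNC(C)(C)C)c(C(=O)O)nn2-c2ccc(Cl)cc2)cc1` has methyl in place of hydrogen on an aromatic carbon, phenyl to 4-methylphenyl (methyl in place of hydrogen on an aromatic carbon). Among the compounds with values here, the one measured step bearing on this is a 7.7-fold higher number from compound 2 to compound 3 (0.89 log units; beyond the scatter), where hydrogen replaces chloro on an aromatic carbon. Read in reverse, that single pair suggests a somewhat smaller move to a lower number in this assay. Compound 4 is expected at 220000 nM, with an estimated range of 70000 nM to 700000 nM. This estimate means an expected 3.0-fold lower number from compound 3 to compound 4 (0.47 log units; beyond the scatter).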

Compound 4, concentration for 50% growth inhibition: > 629000 nM
Compound 4: only a limit was reported; the forecaster's own chance of this, stated with the estimate: 15%; middle value at least 2.8-fold (0.45 log units) from the limit.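

In this assay compound 4 is reported only as a limit: the limit of > 629000 nM in this assay, at which 1 of the 4 values shown sits.

The step from compound 3 cannot be read, so methyl and hydrogen at this place, para to a large group, stay unordered. Against chloro the comparison does hold, with an at least 7.4-fold higher number from compound 2 to compound 4 (0.86 log units; beyond the scatter), so the lower number of compound 2 does not carry over to methyl.

As far as these compounds go, whether fluoro, bromo or trifluoromethyl at this place would keep a number as low as that of compound 2 remains open. A true value for compound 4 is also still lacking.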